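The source may hold more compounds than are shown below. What is called first, only, known or untested is meant among the compounds shown, and "the series" means these compounds.

Measured compounds:
Compound 1 `CCOc1ccccc1-c1ccc(-c2nc3cnccc3c(N[C@H](CC)C(=O)N(C)C)c2C#N)cc1` — 3.7
Compound 2 `CCOc1ccccc1-c1ccc(-c2nc3cnccc3c(C[C@H](C)C(=O)O)c2C#N)cc1` — 2.2
Compound 3 `CC[C@@H](Nc1c(C#N)c(-c2ccc(-c3ccc(F)cc3)cc2)nc2cnccc12)C(N)=O` — 2.7

In a physicochemical assay for lipophilicity, read by HPLC, at pH 7.5 (a higher number here means a more lipophilic compound, a lower number a more polar compound), compound 3 stands second highest of the three; compound 2 gives 2.2, a lower number, and compound 1 gives 3.7, a higher one, both gaps lying beyond the scatter. Going by the values given here, the one step known between two measured compounds is a number 1.50 log units lower from compound 1 to compound 2 (beyond the scatter), a large fall that comes from exchanging the amino-bearing side chain for an acid. It sits at another place on the shared core and tells nothing directly about the change now followed.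

Compound 4 `CC[C@@H](Nc1c(C#N)c(-c2ccc(-c3ccccc3OC)cc2)nc2cnccc12)C(N)=O` is the unmeasured compound. It differs from compound 3 in one place: 2-methoxyphenyl in place of 4-fluorophenyl on an aromatic carbon. Among the compounds with values here, no measured pair shows this exchange, so the expectation rests on the small size of the groups that leave and enter. The step from compound 3 to compound 4 is expected to be small, a number 0.20 log units lower from compound 3 to compound 4 (within the scatter), within the scatter. Compound 4 is therefore estimated at 2.5, in the range 2.1 to 2.9.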

Compound 4, distribution coefficient: 2.7
Beside the measured number, compound 4's estimate is 0.20 log units below it; low and high end bracket the measured number.
By their numbers in this assay, from the lowest: compound 2; then compounds 3 and 4 (each within the scatter of the next); then compound 1.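

In this assay, going by these compounds alone, putting 2-methoxyphenyl in place of 4-fluorophenyl gives no change at the digits printed from compound 3 to compound 4 (within the scatter), the first reading of any change at this aromatic carbon, para to a large group. The earlier step concerned a different place on the shared core, so this pair alone shows that this position can take a group of 8 heavy atoms with 1 hydrogen-bond acceptor in place of one of 7 heavy atoms with 0 acceptors without a reading beyond the scatter. Nothing at hand explains this outcome.

Going by these compounds, a single exchange cannot separate the change of substituent from the change in where it sits on the ring, so 2-fluorophenyl and 4-methoxyphenyl remain open comparisons. On these data alone, whether an amine or a carboxylic acid on this ring would leave the reading as flat also stays open.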